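A few compounds are considered here, and "the series" means these few. Any claim that something is new, unique, unknown or untested is made for them only; others in the source may bear on it.

Measured so far in a functional assay on HCT-15 cells (Homo sapiens) for cytotoxicity, read by MTT assay, with a stated time of 2 days; a lower number here means a stronger inhibitor, a higher number a weaker inhibitor:
Compound 1 `CCN(CC)c1ccc2nc(-c3cccc4ccccc34)[nH]c(=O)c2c1` gives 3210 nM.
Compound 2 `COc1cccc(-c2nc3cc(C)ccc3c(=O)[nH]2)c1` gives 4850 nM.

Compound 1 has the lower of these two numbers, yet its gap to compound 2 lies within the scatter of repeated runs, so the two cannot be told apart. Compound 3 `CN(C)c1ccc2nc(-c3cccc4ccccc34)[nH]c(=O)c2c1` differs from compound 1 in one place: dimethylamino in place of diethylamino on an aromatic carbon. Going by the values given here, no measured pair shows the effect of a comparable change. Putting dimethylamino in place of diethylamino is expected to leave the number in this assay about where it is, with no step beyond the scatter. The estimated value for compound 3 is 3500 nM, likely between 1500 nM and 8000 nM, an expected step of a 1.1-fold higher number from compound 1 to compound 3 (0.04 log units; within the scatter).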

Compound 3, half-maximal inhibitory concentration: 460 nM
Estimate against measurement, compound 3: 7.6-fold (0.88 log units) above; measured number outside the range, below it.
By their numbers in this assay, from the lowest: compound 3; then compounds 1 and 2 (each within the scatter of the next).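

Replacing diethylamino with dimethylamino on this aromatic carbon is not a neutral swap: in this assay it brings a 7.0-fold lower number from compound 1 to compound 3 (0.84 log units; beyond the scatter). Even a change this small in the groups carried on that amine nitrogen can therefore shift the cytotoxicity number clearly on this shared core. Nothing measured here explains why the number moves. A single pair does not make a trend. As far as these compounds go, it remains open whether a plain amine or a methylamino group at this carbon would lower the number further or raise it again.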